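From Trifluoromethyl to Oxan-4-yl: an Expected Step

The compounds below may be only part of what the source reports. "The series", "measured", "known", "first", "only" and "open" are said of these compounds alone.

Measured compounds:
compound 1 `C[C@@H]1CC(=O)Nc2ncnc(N3CCC(c4nc(-c5ccc(F)c(C(F)(F)F)c5)cn4CCN4CCCC4)CC3)c21` gives 3 nM
compound 2 `C[C@@H]1CC(=O)Nc2ncnc(N3CCC(c4nc(C(F)(F)F)cn4CCN4CCCC4)CC3)c21` gives 11 nM

Both were measured in an assay on cells for inhibition of RAC-alpha serine/threonine-protein kinase (Homo sapiens), read by fluorescence polarization, with a stated time of 60 min; on this read-out higher numbers stand for weaker inhibition and lower numbers for stronger inhibition. Compound 2 holds the highest of the two numbers, and its nearest neighbour is compound 1; the change of trifluoromethyl in place of 4-fluoro-3-(trifluoromethyl)phenyl gave a 3.7-fold higher number from compound 1 to compound 2 (0.56 log units; beyond the scatter), a modest step.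

Compound 3 `C[C@@H]1CC(=O)Nc2ncnc(N3CCC(c4nc(C5CCOCC5)cn4CCN4CCCC4)CC3)c21` has not yet been measured. It differs from compound 2 in one place: oxan-4-yl in place of trifluoromethyl on an aromatic carbon. Within the data shown here, the only measured step, the one from compound 1 to compound 2, concerns a different exchange at the same aromatic carbon and bears on this change only loosely, showing that the group at this position moves the number by a modest amount. Compound 3 is therefore expected to stay close to compound 2, with a slight lean toward a lower number, and the step from compound 2 to compound 3 is estimated as a 1.4-fold lower number from compound 2 to compound 3 (0.14 log units; within the scatter). For compound 3 the estimate in this assay is 8 nM, within a range from 2.5 nM to 30 nM.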

Compound 3, half-maximal inhibitory concentration: 4 nM
Compound 3: the middle estimate sits 2.0-fold (0.30 log units) above what was measured, within the range that was stated.
By their numbers in this assay, from the lowest: compounds 1 and 3 (each within the scatter of the next); then compound 2.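

In this assay, oxan-4-yl in place of trifluoromethyl on this aromatic carbon gave a 2.8-fold lower number from compound 2 to compound 3 (0.44 log units; beyond the scatter), so a group without an aromatic ring can move the number beyond the scatter at this position. Against the larger aromatic substituent, the same group gave a 1.3-fold higher number from compound 1 to compound 3 (0.12 log units; within the scatter), which means that 4-fluoro-3-(trifluoromethyl)phenyl and oxan-4-yl cannot be told apart on this read-out, and that among these three compounds an aromatic ring at this carbon is not required for a number at the low end. No supporting data accompany these numbers to account for the difference between either ring-bearing group and trifluoromethyl.

The three compounds leave open whether the ring oxygen of oxan-4-yl matters, which a cyclohexyl group at this carbon would test, and whether a smaller ring such as cyclopropyl or a ring amine such as piperidin-4-yl would give a similar number. On these data alone, the 2-(pyrrolidin-1-yl)ethyl group and the shared core stay the same throughout, so it also remains open whether this exchange would give a similar step alongside a longer chain ending in a morpholine.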